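Benzylamine aryl swaps on the bis(trifluoromethyl)sulfonamide series

The compounds below may be only part of what the source reports. "The series", "measured", "known", "first", "only" and "open" are said of these compounds alone.

Measured so far:
compound 1 `O=S(=O)(NCCCNCc1ccccc1Cl)c1cc(C(F)(F)F)cc(C(F)(F)F)c1` — 11000 nM
compound 2 `COc1ccc(CNCCCNS(=O)(=O)c2cc(C(F)(F)F)cc(C(F)(F)F)c2)cc1OC` — 2800 nM
compound 3 `O=S(=O)(NCCCNCc1ccc(C(F)(F)F)cc1)c1cc(C(F)(F)F)cc(C(F)(F)F)c1` — 2500 nM

In a functional assay on MIA PaCa-2 cells (Homo sapiens) for inhibition, read by MTT assay, with a stated time of 72 h (a lower number here means a stronger inhibitor of growth, a higher number a weaker inhibitor of growth), compound 3 gives the lowest of the three numbers, but its gap to compound 2 lies within the scatter (a 1.1-fold lower number from compound 2 to compound 3 (0.05 log units; within the scatter)); only compound 1 sits clearly apart (a 4.4-fold lower number from compound 1 to compound 3 (0.64 log units; beyond the scatter), a 3.9-fold lower number from compound 1 to compound 2 (0.59 log units; beyond the scatter)). Compound 4 `COc1ccc(CNCCCNS(=O)(=O)c2cc(C(F)(F)F)cc(C(F)(F)F)c2)cc1` differs from compound 3 by methoxy in place of trifluoromethyl on an aromatic carbon. The step bearing on this is the swap between compound 2 and compound 3, which was within the scatter; a single methoxy in place of trifluoromethyl is therefore expected to move this assay little, if at all. Compound 4 is estimated at 2800 nM (range 1400 nM to 5600 nM), an expected step of a 1.1-fold higher number from compound 3 to compound 4 (0.05 log units; within the scatter).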

Compound 4, concentration for 50% growth inhibition: 2500 nM
Compound 4: the middle estimate sits 1.1-fold (0.05 log units) above what was measured; the range from low to high includes it.
By their numbers in this assay, from the lowest: compounds 3, 4 and 2 (each within the scatter of the next); then compound 1.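

In this assay, within the data shown here, the single swap of trifluoromethyl for methoxy on the aromatic carbon gives no change at the digits printed from compound 3 to compound 4 (within the scatter), the first direct reading of this change at this place. Hydrogen in place of methoxy on an aromatic carbon gives a 1.1-fold lower number from compound 2 to compound 4 (0.05 log units; within the scatter), so the second methoxy of compound 2 adds nothing measurable. The gap to the 2-chlorophenyl analogue stands as a 4.4-fold lower number from compound 1 to compound 4 (0.64 log units; beyond the scatter), so 4-methoxyphenyl joins the two other aryl groups on the same side of compound 1.

No evidence bears on why these swaps leave the growth inhibition unmoved. Still open, on these data alone, is whether an amine or a carboxylic acid on this aromatic carbon, or a longer chain linking the sulfonamide to the benzylamine, would shift the number.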